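Compound 2 and the 1-phenylethyl swap

The compounds below may be only part of what the source reports. "The series", "measured", "known", "first", "only" and "open" are said of these compounds alone.

Among the measured compounds shown here, in a functional assay for inhibition, with Rattus norvegicus as the target (a higher number here means a weaker inhibitor, a lower number a stronger inhibitor), compound 2 (`CC(C)/N=c1\c(O)c(O)\c1=N/c1ccc(C#N)cc1`) gives 13700 nM, its only single number; a further entry for compound 2 carries no single number. The only other measured reference is compound 1 (`C[C@@H](/N=c1\c(O)c(O)\c1=N/c1ccc(C#N)cc1)C(C)(C)C`), which gives 370 nM; 24300 nM (2 entries). Compound 2 therefore sits inside the span of compound 1, so no order can be drawn between the two. That span, (the several entries of compound 1 in this assay, 370 nM; 24300 nM (2 entries)), is wide and makes compound 1 a poor anchor. For the measured compounds named here, no single-place step between measured compounds is available to calibrate the change.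

Compound 3 (`C[C@H](/N=c1\c(O)c(O)\c1=N/c1ccc(C#N)cc1)c1ccccc1`) carries 1-phenylethyl in place of isopropyl on a double-bonded nitrogen. Its new group is larger, as is the group on compound 1, whose lower entry in 370 nM; 24300 nM (2 entries) lies well under the value of compound 2. A move towards stronger inhibition in this assay is therefore expected, though with low confidence. The expected change is a 5.5-fold lower number from compound 2 to compound 3 (0.74 log units; beyond the scatter), a lower number than before. For compound 3 the estimated value is 2500 nM, with an expected range of 250 nM to 20000 nM.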

Compound 3, half-maximal inhibitory concentration: > 30000 nM
Compound 3: no number, only a limit (the forecaster's own chance of this, stated with the estimate: 10%); middle value at least 12-fold (1.07 log units) from the limit.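

In this assay, compound 3 stands at a limit of the assay, > 30000 nM, and not at a number. Among the compounds shown here, this still gives the first readable step at this place on a double-bonded nitrogen: 1-phenylethyl in place of isopropyl brings an at least 2.1-fold higher number from compound 2 to compound 3 (0.34 log units; beyond the scatter), so this exchange, which adds a six-membered aromatic ring of carbon only and a defined stereocentre, goes towards weaker inhibition, and a larger group at this place does not by itself bring stronger inhibition. The step marks only a minimum, and the full size of the loss cannot be read: the limit of > 30000 nM in this assay, at which 1 of the 3 values shown sits.

From the compounds shown here alone, compound 1 remains a poor guide to how other groups at this place behave: the several entries of compound 1 in this assay, 370 nM; 24300 nM (2 entries) Whether the loss follows the aromatic ring, the added carbons or the stereocentre stays open, as does the behaviour of a cyclohexyl group, a benzyl group or a chain ending in a carboxylic acid on the same nitrogen.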